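The compounds below may be only part of what the source reports. "The series", "measured", "known", "first", "only" and "open" are said of these compounds alone.

Compound 2 `O=C(O)Cc1sc(C(c2ccccc2)c2ccc(Cl)cc2)nc1-c1ccc(Cl)cc1` carries a 4-chlorophenyl on the saturated chain carbon bound to two aromatic carbons. In an in vitro functional assay on HEK285-7 cells for antagonist activity at prostaglandin D2 receptor 2 (Homo sapiens), read by BRET and beta-arrestin recruitment (on this read-out higher numbers stand for larger maximal responses and lower numbers for smaller maximal responses), compound 2 gives 80%, the higher of the two numbers measured, while compound 1 `O=C(O)Cc1sc(Cc2ccccc2-c2ccccc2)nc1-c1ccc(Cl)cc1` gives 50%, a value that falls lower by a gap beyond the usual scatter of this assay. Compound 3 `O=C(O)Cc1sc(Cc2ccccc2)nc1-c1ccc(Cl)cc1` has not yet been measured in this assay. It differs from compound 2 in one place: hydrogen in place of 4-chlorophenyl on a saturated chain carbon bound to two aromatic carbons. Among the measured compounds shown here, no step between two measured compounds is available for this change, so only the two values measured so far can guide an expectation. Since compound 1, which also lacks a 4-chlorophenyl at that carbon, gives 50%, a drop beyond the scatter is expected for this assay, a number 30 percentage points lower from compound 2 to compound 3 (beyond the scatter). Compound 3 is therefore estimated to reach 50% in this assay, within a range from 30% to 70%.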

Compound 3, largest response reached (reported as efficacy), in percent of the reference or control that the assay uses: 50%
Estimate against measurement, compound 3: no gap at the digits printed; the range from low to high includes it.
By their numbers in this assay, from the lowest: compounds 1 and 3 (each within the scatter of the next); then compound 2.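

In this assay, among the compounds shown here, hydrogen in place of 4-chlorophenyl on a saturated chain carbon bound to two aromatic carbons gives a number 30 percentage points lower from compound 2 to compound 3 (beyond the scatter), the first direct reading of this change at this position. Hydrogen in place of phenyl on an aromatic carbon gives no change at the digits printed from compound 1 to compound 3 (within the scatter), so among these three compounds only the change at the saturated chain carbon moves the number beyond the scatter. Nothing available explains why the response differs at this position.

The compounds shown leave open whether the chlorine or the aromatic ring of the 4-chlorophenyl accounts for the step, a question that an unsubstituted phenyl on the same carbon would address. They also leave open how a methyl, a hydroxyl or an amine on that carbon would compare.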